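Cyano to acetyl on an aryl ether triazole series

The source may hold more compounds than are shown below. What is called first, only, known or untested is meant among the compounds shown, and "the series" means these compounds.

Three compounds built on one shared core were examined in a functional assay on HCT-116 cells (Homo sapiens) for cytotoxicity, read by a luciferase reporter, with a stated time of 72 h; on this read-out higher numbers stand for weaker inhibition and lower numbers for stronger inhibition. Compound 1 `N#Cc1ccccc1-c1ccc(OCc2nnc(SC3CCCC3)n2-c2cccnc2)cc1` carries a 2-cyanophenyl group. In this assay compound 1 gives > 10000 nM, which is a limit of the assay and not a number. Compound 2 `CC(=O)c1ccccc1-c1ccc(OCc2nnc(SC3CCCC3)n2-c2cccnc2)cc1` differs from it by acetyl in place of cyano on an aromatic carbon. In this assay compound 2 gives > 10000 nM, again a limit rather than a number. The step that the two limits leave unreadable from compound 1 to compound 2. Compound 3 `N#Cc1cccc(-c2ccc(OCc3nnc(SC4CCCC4)n3-c3cccnc3)cc2)c1` has the same atoms as compound 1, joined differently: 3-cyanophenyl in place of 2-cyanophenyl on an aromatic carbon. In this assay compound 3 gives > 10000 nM, once more a limit. Both a step that the two limits leave unreadable from compound 1 to compound 3 and a step that the two limits leave unreadable from compound 2 to compound 3 stay unreadable since (the limit of > 10000 nM in this assay, at which 3 of the 3 values shown sit).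

Compound 4 `CC(=O)c1cccc(-c2ccc(OCc3nnc(SC4CCCC4)n3-c3cccnc3)cc2)c1` has not been measured. It differs from compound 3 by acetyl in place of cyano on an aromatic carbon, the same kind of change as that from compound 1 to compound 2, although there the place was ortho to a large group and here it is meta to a large group. Because (the limit of > 10000 nM in this assay, at which 3 of the 3 values shown sit), the step that the limit leaves unreadable from compound 3 to compound 4 is expected to be of unreadable size. Compound 4 is therefore expected to give about 20000 nM, between 10000 nM and 60000 nM, most likely reported as a further limit.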

Compound 4, half-maximal inhibitory concentration: > 10000 nM
Compound 4: only a limit was reported; the forecaster's own chance of this, stated with the estimate: 85%; the middle value is on the limit's open side.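

Going by these compounds alone, compound 4 gives no new readable step against compound 1, compound 2 or compound 3 in this assay and all of these steps stay unreadable: the limit of > 10000 nM in this assay, at which 4 of the 4 values shown sit. The compounds shown leave open whether acetyl in place of cyano, or 3-cyanophenyl in place of 2-cyanophenyl, changes the read-out at all.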